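This account rests on a few compounds, and the source may have more. Where it says the series, first, only, none or still open, it means among the compounds named here.

In a toxicity assay on HEK-293T cells (Homo sapiens) for cytotoxicity, read by MTT assay, with a stated time of 72 h (on this read-out higher numbers stand for weaker inhibition and lower numbers for stronger inhibition), compound 2 (`O=C1c2c[n+]([O-])c3ccccc3c2C(=O)c2c1c1ccccc1n2Cc1cn([C@@H]2C[C@H](O)[C@@H](CO)O2)nn1`) gives 820 nM, the highest of the three numbers. Compound 1 (`O=C1c2c[n+]([O-])c3ccccc3c2C(=O)c2c1c1ccccc1n2CCCCn1ccnc1`) gives 280 nM and compound 3 (`CN1CCN(CCCCn2c3c(c4ccccc42)C(=O)c2c[n+]([O-])c4ccccc4c2C3=O)CC1`) gives 100 nM. The gaps from compound 2 to these two compounds both lie beyond the scatter. The move to compound 4 (`CC1(C)O[C@@H](CO)[C@H](Cn2cc(Cn3c4c(c5ccccc53)C(=O)c3c[n+]([O-])c5ccccc5c3C4=O)nn2)O1`) is (5-(hydroxymethyl)-2,2-dimethyl-1,3-dioxolan-4-yl)methyl in place of 4-hydroxy-5-(hydroxymethyl)oxolan-2-yl on an aromatic nitrogen, a change on an aromatic nitrogen of the five-membered aromatic ring with 3 nitrogen. Among the measured compounds shown here, no measured step changes this group. For the measured compounds named here, the only guide is a 2.8-fold lower number from compound 1 to compound 3 (0.45 log units; beyond the scatter), a modest step at a different side chain. A step no larger than that one is expected in this assay, toward a lower number, given that compound 2 at 820 nM tops the three. The estimated step is a 2.0-fold lower number from compound 2 to compound 4 (0.29 log units; within the scatter). For compound 4 the estimate is 420 nM, with an expected range of 130 nM to 1300 nM.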

Compound 4, half-maximal inhibitory concentration: 120 nM
The estimate for compound 4 lay 3.5-fold (0.54 log units) above the measured number, outside the stated range (below it).
By their numbers in this assay, from the lowest: compounds 3 and 4 (each within the scatter of the next); then compound 1; then compound 2.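

In this assay, the group on the aromatic nitrogen of the five-membered aromatic ring with 3 nitrogen clearly affects the read-out: (5-(hydroxymethyl)-2,2-dimethyl-1,3-dioxolan-4-yl)methyl in place of 4-hydroxy-5-(hydroxymethyl)oxolan-2-yl gives a 6.8-fold lower number from compound 2 to compound 4 (0.83 log units; beyond the scatter). The change alters the ring, the heavy-atom count, the hydrogen-bond donors and the stereocentres together, so the step belongs to the whole group and not to any one part. No measurement available here accounts for the step.

Which part of the group carries the step remains open. Also open, on these data alone, is how an amine or a plain alkyl chain on this nitrogen would compare.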